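From chloro to methoxy on the aromatic ring

The source may report more compounds than this note shows. Statements on the series, on what has been measured and on what is new or still open speak of the compounds shown alone.

- compound 1 (`O=C(CCc1nc2ccccc2c(=O)[nH]1)N/N=C/c1ccc(O)cc1`): (238000000 nM)
- compound 2 (`O=C(CCc1nc2ccccc2c(=O)[nH]1)N/N=C/c1ccc(Cl)cc1`): (381000000 nM)
- compound 3 (`COc1cc(/C=N/NC(=O)CCc2nc3ccccc3c(=O)[nH]2)cc(OC)c1O`): (126000000 nM)

In a physicochemical assay, read by spectrophotometry, with a stated time of 30 min (on this read-out lower numbers stand for stronger inhibition and higher numbers for weaker inhibition), compound 2 cannot be told apart from compound 1, while compound 3 gives a clearly lower number. Compound 4 (`COc1ccc(/C=N/NC(=O)CCc2nc3ccccc3c(=O)[nH]2)cc1`) carries methoxy in place of chloro on an aromatic carbon, para to a large group (methoxy in place of chloro on an aromatic carbon). Among the measured compounds shown here, the one measured step at a single place swaps hydroxy for chloro (a 1.6-fold higher number from compound 1 to compound 2 (0.20 log units; within the scatter)) and stays within the scatter. Compound 3 (126000000 nM) also carries methoxy, but it differs from compound 2 in more than one place, so it offers only a weak hint of a lower number. A small step, not clearly beyond the scatter, is therefore expected (a 1.7-fold lower number from compound 2 to compound 4 (0.22 log units; within the scatter)). For compound 4 the estimated value is 230000000 nM (expected range 110000000 nM to 420000000 nM).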

Compound 4, half-maximal inhibitory concentration: 214000000 nM
Compound 4: the middle estimate sits 1.1-fold (0.03 log units) above what was measured; the measured number falls inside the stated range.
By their numbers in this assay, from the lowest: compounds 3, 4, 1 and 2 (each within the scatter of the next, the first and the last beyond it).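

With methoxy in place of chloro on an aromatic carbon, para to a large group, the number moves by a 1.8-fold lower number from compound 2 to compound 4 (0.25 log units; within the scatter) in this assay, so this swap stays within the scatter. Methyl in place of hydrogen on the oxygen at that position gives a 1.1-fold lower number from compound 1 to compound 4 (0.05 log units; within the scatter) and also stays within the scatter. Chloro, hydroxy and methoxy at this position therefore cannot be told apart, which the earlier single step could not show for methoxy.

From the compounds shown here alone, whether an amine or a carboxylic acid here would give a clearly different number remains open. No other evidence bears on these results.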